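From 2-chlorophenyl to (2-fluorophenyl)carbonyl on the hydrazide

The source may hold more compounds than are shown below. What is called first, only, known or untested is meant among the compounds shown, and "the series" means these compounds.

Of the compounds shown here, two that share a sulfonamide-linked core have been tested in a functional assay on MDA-MB-231 cells (Homo sapiens) for antiproliferative activity, read by MTT assay, with a stated time of 24 h; on this read-out lower numbers stand for stronger inhibition and higher numbers for weaker inhibition. Compound 2 `O=C(NNc1ccccc1Cl)c1cccc(NS(=O)(=O)c2cnc(O)nc2O)c1` gives 2090 nM in this assay. Compound 1 `O=C(NNc1ccccc1F)c1ccc(NS(=O)(=O)c2cnc(O)nc2O)cc1` reaches only > 20000 nM, which is a limit of the assay and not a number. Compound 2 therefore holds the only number shown, while the other result is the limit (the limit of > 20000 nM in this assay, at which 1 of the 2 values shown sits). Compound 3 `O=C(NNC(=O)c1ccccc1F)c1cccc(NS(=O)(=O)c2cnc(O)nc2O)c1` has not yet been measured. It differs from compound 2 in one place: (2-fluorophenyl)carbonyl in place of 2-chlorophenyl on an amine nitrogen. Among the measured compounds shown here, no step between two measured compounds exists here, so the size of the change in this assay rests on expectation alone. The step expected is a 1.9-fold higher number from compound 2 to compound 3 (0.28 log units; within the scatter), a modest loss that might still fall within the scatter. For compound 3 the estimate is 4000 nM, expected to lie between 1000 nM and 20000 nM.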

Compound 3, half-maximal inhibitory concentration: > 20000 nM
Compound 3: a limit, no number; the forecaster's own chance of this, stated with the estimate: 25%; middle value at least 5.0-fold (0.69 log units) away from the limit.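

Among the compounds shown here, this is the first step between two measured compounds, and it shows that this position on the hydrazide tolerates the change poorly: (2-fluorophenyl)carbonyl in place of 2-chlorophenyl on an amine nitrogen gives an at least 9.5-fold higher number from compound 2 to compound 3 (0.98 log units; beyond the scatter) in this assay. Going by these compounds, the result for compound 3 is a limit of the assay and not a number, so the true size of the step stays unknown. Among the compounds shown, only compound 2 gives a number: the limit of > 20000 nM in this assay, at which 2 of the 3 values shown sit.

The change brings in a carbonyl and replaces chlorine with fluorine in a single move, and these compounds cannot separate the two. A (2-chlorophenyl)carbonyl or a plain phenyl on the same amine nitrogen would show whether the carbonyl alone accounts for the loss.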